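This account rests on a few compounds, and the source may have more. Where it says the series, first, only, none or still open, it means among the compounds named here.

Measured in a functional assay on DU-145 cells (Homo sapiens) for inhibition, read by trypan blue exclusion, with a stated time of 96 h; on this read-out lower numbers stand for stronger inhibition of growth and higher numbers for weaker inhibition of growth:
- Compound 1 (`O=C(/C(=C\c1ccc(O)cc1O)Sc1ccc(Br)cc1)c1ccc(Cl)cc1`): 50000 nM
- Compound 2 (`CN(C)c1ccc(/C=C(\C(=O)c2ccc(Cl)cc2)S(=O)(=O)c2ccc(Br)cc2)cc1`): > 100000 nM (a limit)
- Compound 3 (`Cc1ccc(S(=O)(=O)/C(=C/c2ccc(N(C)C)cc2)C(=O)c2ccc(Cl)cc2)cc1`): > 100000 nM (a limit)

Compound 3 has no number on this read-out, only the limit > 100000 nM. It stands with compound 2 at the limit of > 100000 nM in this assay, at which 2 of the 3 values shown sit, and compound 1 is the only one of the three with a number.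

The next compound is compound 4 (`CN(C)c1ccc(/C=C(/Sc2ccc(Br)cc2)C(=O)c2ccc(Cl)cc2)cc1`). The change from compound 3 is (4-bromophenyl)sulfanyl in place of (4-methylphenyl)sulfonyl on a double-bonded chain carbon bound to a carbonyl carbon and a double-bonded chain carbon.

Among the compounds with values here, the one measured step, methyl in place of bromo, is a step that the two limits leave unreadable from compound 2 to compound 3 and so offers no size to carry over. The nearest guide is compound 1, which also carries (4-bromophenyl)sulfanyl and gives 50000 nM, although it differs from compound 4 elsewhere in the structure. A modest gain in inhibition of growth is therefore expected, and this assay may still return only a limit. The expected move is an at least 2.0-fold lower number from compound 3 to compound 4 (0.30 log units; that floor lies within the scatter), towards stronger inhibition. For compound 4 the estimate is 50000 nM, with an expected range of 15000 nM to 100000 nM.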

Compound 4, concentration for 50% growth inhibition: > 100000 nM
Compound 4: no number, only a limit (the forecaster's own chance of this, stated with the estimate: 35%); middle value at least 2.0-fold (0.30 log units) away from the limit.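

In this assay, (4-bromophenyl)sulfanyl in place of (4-methylphenyl)sulfonyl does not yield a number: compound 4 gives only a limit, > 100000 nM. The steps from compound 2 and from compound 3 to compound 4 cannot be read, with limits at both ends, and the set now gathers at one ceiling: the limit of > 100000 nM in this assay, at which 3 of the 4 values shown sit. Within the data shown here, the one readable step is 4-(dimethylamino)phenyl in place of 2,4-dihydroxyphenyl on a double-bonded chain carbon bound to a double-bonded chain carbon, an at least 2.0-fold higher number from compound 1 to compound 4 (0.30 log units; that floor lies within the scatter), so with (4-bromophenyl)sulfanyl held constant, the number seen for compound 1 does not carry over to the 4-(dimethylamino)phenyl partner, although this floor fixes no size for the step.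

Among these compounds, whether sulfanyl and sulfonyl differ at all remains open, as the only pair that differs there has no number on either side. Also open, from the compounds shown here alone, is what a 4-aminophenyl or a 4-carboxyphenyl group would give in place of 2,4-dihydroxyphenyl on a double-bonded chain carbon bound to a double-bonded chain carbon, and whether either would bring a number in this assay.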